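Chloro for hydrogen: a matched step across two cores

This account rests on a few compounds, and the source may have more. Where it says the series, first, only, none or still open, it means among the compounds named here.

Measured in a functional assay on KB cells (Homo sapiens) for cytotoxicity; on this read-out higher numbers stand for weaker inhibition and lower numbers for stronger inhibition:
compound 1 `O=[N+]([O-])c1ccc(Oc2c(Cl)cc(S(=O)(=O)N/C(=N\O)Nc3ccc(Cl)cc3)cc2Cl)cc1`: 12 ug/mL
compound 2 `O=[N+]([O-])c1ccc(Oc2c(Cl)cc(S(=O)(=O)N/C(=N\O)Nc3ccc(Cl)cc3)cc2Cl)c(Cl)c1`: 7 ug/mL
compound 3 `Cc1c(S(=O)(=O)/N=C(\S)Nc2ccc(Cl)cc2)sc2ccc(Cl)cc12`: 61 ug/mL

Compound 2 differs from compound 1 by chloro in place of hydrogen on an aromatic carbon, and the step this made is a 1.7-fold lower number from compound 1 to compound 2 (0.23 log units; within the scatter). Compound 3 rests on a different core; the difference between the two cores is not broken down here. Compound 3 has the highest number of the three, beyond the scatter from both compound 1 and compound 2.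

Compound 4 `Cc1c(S(=O)(=O)/N=C(\S)Nc2ccc(Cl)c(Cl)c2)sc2ccc(Cl)cc12` is not yet measured. It differs from compound 3 by chloro in place of hydrogen on an aromatic carbon, the same kind of change as from compound 1 to compound 2, though the surroundings differ: in compound 2 the new chloro sits ortho to a large group and meta to a nitro group, in compound 4 ortho to a chloro group and meta to a large group.

Going by the step from compound 1 to compound 2, the expected step from compound 3 to compound 4 in this assay is a 1.5-fold lower number from compound 3 to compound 4 (0.18 log units; within the scatter), a modest shift. For the measured compounds named here, compound 4 is thus expected to give about 40 ug/mL, within a range from 15 ug/mL to 90 ug/mL, because compound 3 gives 61 ug/mL and the only analogous step is a 1.7-fold lower number from compound 1 to compound 2 (0.23 log units; within the scatter).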

Compound 4, half-maximal inhibitory concentration: 25 ug/mL
Beside the measured number, compound 4's estimate is 1.6-fold (0.20 log units) above it; measured number inside the range.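

In this assay, chloro in place of hydrogen on an aromatic carbon gives a 2.4-fold lower number from compound 3 to compound 4 (0.39 log units; beyond the scatter), so the number also goes down on this second core. Set beside the earlier step, the change carries from one core to the other with no gap that can be told apart from scatter: the same change on two cores in this assay, a 1.7-fold lower number (0.23 log units; within the scatter) from compound 1 to compound 2 and a 2.4-fold lower number (0.39 log units; beyond the scatter) from compound 3 to compound 4, 1.4-fold (0.15 log units) apart, within the scatter of two such steps. This rests on only two pairs, the earlier step lies within the scatter on its own, and the new chloro has different surroundings in each pair, so neither a general rule for the series nor a cause for the step is shown.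

From the compounds shown here alone, it remains open whether a bromo, methoxy or amine group on the same aromatic carbon would move the number as chloro does. Going by these compounds, it is also open whether the step would hold on any further core.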